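From 3-(pyrrolidin-1-yl)propyl to 3-(diethylamino)propyl

This account rests on a few compounds, and the source may have more. Where it says the series, first, only, none or still open, it means among the compounds named here.

Values in an ADME assay on L6 cells (Rattus norvegicus) for cytotoxicity, read by fluorescence and resazurin assay, with a stated time of 6 days (on this read-out higher numbers stand for weaker inhibition and lower numbers for stronger inhibition), so far
- compound 1 `N#CCCc1cc2cc(Cl)ccc2nc1-c1cccs1` gives "not determined" (no result reported)
- compound 2 `Clc1ccc2nc(-c3cccs3)c(CCCN3CCCC3)cc2c1` gives 9440 nM

Within the data shown here, compound 2 holds the only number, so it has no rank yet. Still unmeasured is compound 3 `CCN(CC)CCCc1cc2cc(Cl)ccc2nc1-c1cccs1` with the change diethylamino in place of pyrrolidin-1-yl on a saturated chain carbon, three bonds along the chain from an aromatic carbon on a saturated chain carbon, three bonds along the chain from an aromatic carbon. Among the measured compounds shown here, no measured pair shows this kind of change in this assay so no shift in either direction beyond the usual scatter is expected. The expected move a 1.1-fold higher number from compound 2 to compound 3 (0.03 log units; within the scatter) stays small. For compound 3 the estimate is 10000 nM with 4500 nM to 25000 nM as the expected range.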

Compound 3, half-maximal inhibitory concentration: 14700 nM
Compound 3: the middle estimate sits 1.5-fold (0.17 log units) below what was measured, and the stated range covers the measured number.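

In this assay, diethylamino in place of pyrrolidin-1-yl gives a 1.6-fold higher number from compound 2 to compound 3 (0.19 log units; within the scatter). This first readable step at this position shows that, on a saturated chain carbon, three bonds along the chain from an aromatic carbon, the open diethylamino group and the ring of pyrrolidin-1-yl cannot be told apart on this read-out. Nothing measured here offers an explanation for this result. Still open, as far as these compounds go, is whether a morpholine or piperidine ring at the end of the propyl chain would read the same. From the compounds shown here alone, a shorter ethyl chain carrying diethylamino is equally open.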